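The compounds below may be only part of what the source reports. "The series", "measured", "known", "first", "only" and "open" are said of these compounds alone.

Working notes on the series. Compound 1 `COc1cc(Cn2cc(COc3cccc(/C=C4\C(=O)Nc5ccccc54)c3)nn2)cc(OC)c1` gives in a functional assay on MDA-MB-231 cells (Homo sapiens) for inhibition, read by MTT assay, with a stated time of 48 h (a lower number here means a stronger inhibitor, a higher number a weaker inhibitor), only a limit of the assay, > 50000 nM. Compound 2 `O=C1Nc2ccc(F)cc2/C1=C\c1cccc(OCc2cn(Cc3ccccc3)nn2)c1` likewise returns in this assay a limit of the assay, > 50000 nM. Among the measured compounds shown here, both values shown sit at the same limit (the limit of > 50000 nM in this assay, at which 2 of the 2 values shown sit), so compound 2 stands at the floor of what this assay reports, and no measured step between compounds is available to guide the next change. Compound 3 `O=C1Nc2ccc([N+](=O)[O-])cc2/C1=C\c1cccc(OCc2cn(Cc3ccccc3)nn2)c1` differs from compound 2 by nitro in place of fluoro on an aromatic carbon. With nothing measured to lean on, the expected step of an at least 1.1-fold lower number from compound 2 to compound 3 (0.04 log units; that floor lies within the scatter) in this assay is small, in either direction, and most likely not beyond the scatter, with a limit again the most probable outcome. The estimate for compound 3 in this assay is 45000 nM, expected to fall between 12000 nM and 100000 nM.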

Compound 3, half-maximal inhibitory concentration: > 50000 nM
Compound 3 ended at the assay's limit; the forecaster's own chance of this, stated with the estimate: 65%; middle value at least 1.1-fold (0.04 log units) from the limit.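

Compound 2 and compound 3 both return only a limit of the assay in this assay, so the step for nitro in place of fluoro cannot be read: the limit of > 50000 nM in this assay, at which 3 of the 3 values shown sit. The compounds shown leave open whether any change to the shared core yields a readable value in this assay.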